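A few compounds are considered here, and "the series" means these few. Any claim that something is new, unique, unknown or untested is made for them only; others in the source may bear on it.

Measured so far:
compound 1 `CCC(=O)N1CCC(c2cc(OC)ccc2N)=N1` — 20.4%
compound 2 `COc1ccc(N)c(C2=NN(C(=O)C3CC3)CC2)c1` — 19.9%

In an assay on isolated protein for inhibition of Nitric oxide synthase, inducible (Homo sapiens), with a stated time of 30 min, tested at 1 mM (a higher number here means more inhibition at the concentration tested (going by the name of the read-out), a lower number less inhibition), compound 2 gives 19.9%, and it stands with compound 1 within the usual scatter of each other, as the step of a number 0.5 percentage points lower from compound 1 to compound 2 (within the scatter) shows. Compound 3 `COc1ccc(N)c(C2=NN(C(=O)C3CCC3)CC2)c1` differs from compound 2 by cyclobutyl in place of cyclopropyl on a carbonyl carbon. Going by the values given here, the only measured step that bears on this change is a number 0.5 percentage points lower from compound 1 to compound 2 (within the scatter), also on a carbonyl carbon, and it stayed within the scatter; no change of ring size has been measured. Compound 3 is therefore expected to show no step beyond the scatter, a number 0.1 percentage points higher from compound 2 to compound 3 (within the scatter), with an estimated 20% and a range of 8% to 32%.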

Compound 3, a percentage reported as inhibition, at one concentration (the size of the read-out at that concentration, not a potency): 1.91%
For compound 3 the middle estimate is 18.1 percentage points above the measured one; measured number outside the range, below it.
By their numbers in this assay, from the lowest: compound 3; then compounds 2 and 1 (each within the scatter of the next).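

In this assay, going by these compounds alone, the group on the carbonyl carbon is not indifferent: the step of a number 18 percentage points lower from compound 2 to compound 3 (beyond the scatter) with cyclobutyl in place of cyclopropyl and the step of a number 18.5 percentage points lower from compound 1 to compound 3 (beyond the scatter) with cyclobutyl in place of ethyl are the first here beyond the scatter. Ethyl and cyclopropyl gave numbers within the scatter of each other, so only the cyclobutyl group separates itself at this position. No measurement at hand gives a reason for this drop. Going by these compounds, whether it continues with a larger ring such as cyclopentyl stays open. So does whether an open chain such as butyl behaves like cyclobutyl.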